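The source may report more compounds than this note shows. Statements on the series, on what has been measured and on what is new or still open speak of the compounds shown alone.

Compound 2 `COc1cc2ncnc(-n3nc(-c4ccccn4)nc3N)c2cc1N` carries an amino group on the shared core. In an assay on MCF7 cells for inhibition of Serine-protein kinase ATM (Homo sapiens), read by immunofluorescence, with a stated time of 1 h (on this read-out higher numbers stand for weaker inhibition and lower numbers for stronger inhibition), compound 2 gives only a limit of the assay, > 40000 nM. Compound 1 `Nc1cc2c(-n3nc(-c4ccccn4)nc3N)ncnc2cc1Cl` likewise gives only a limit in this assay, > 40000 nM. The step from compound 1 to compound 2 a step that the two limits leave unreadable from compound 1 to compound 2 is therefore not readable; both values sit at the limit of > 40000 nM in this assay, at which 2 of the 3 values shown sit. Among the compounds with values here, compound 3 `COc1cc2ncnc(-n3nc(-c4cccnc4)nc3N)c2cc1OC`, which has no amino group and a pyridyl group joined differently, gives 15000 nM in this assay, and no single-place step connects it to compound 2.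

Compound 4 `CCN(CC)C(=O)COc1cc2c(-n3nc(-c4ccccn4)nc3N)ncnc2cc1OC` differs from compound 2 by (diethylcarbamoyl)methoxy in place of amino on an aromatic carbon. Within the data shown here, no measured step bears on this change: the one recorded step is unreadable at both ends, and compound 3 shows only that a member of this core without the amino group reaches a numerical value. The expectation for compound 4 is accordingly wide, spanning a value near that of compound 3 and a renewed limit. Compound 4 is estimated at 20000 nM, between 3000 nM and 60000 nM. The step from compound 2 to compound 4 that this estimate implies is an at least 2.0-fold lower number from compound 2 to compound 4 (0.30 log units; that floor lies within the scatter), expected without a measured analogue to support it.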

Compound 4, half-maximal inhibitory concentration: 5300 nM
For compound 4 the middle estimate is 3.8-fold (0.58 log units) above the measured one, within the range that was stated.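

Placing (diethylcarbamoyl)methoxy instead of amino on this aromatic carbon, ortho to a methoxy group, gives an at least 7.5-fold lower number from compound 2 to compound 4 (0.87 log units; beyond the scatter) in this assay, the first readable step at this position. The change swaps 1 heavy atom for 9 heavy atoms and removes the hydrogen-bond donor of the amino group, yet the number falls rather than rises, so this carbon accepts a far larger group without a loss on this read-out. The step has only a floor and no full size because compound 2 gives a limit and not a number: the limit of > 40000 nM in this assay, at which 2 of the 4 values shown sit.

The compounds shown leave open which part of the chain goes with the lower number, since a plain hydroxyl, the carboxylic acid or a smaller dimethylamide could stand on the same carbon. They also leave open whether a basic amine at the end of a longer chain would lower the number further.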